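The compounds below may be only part of what the source reports. "The series", "measured", "known", "first", "only" and "open" are said of these compounds alone.

Measured so far in a functional assay on OVCAR cells (Homo sapiens) for inhibition, read by MTT assay, with a stated time of 48 h; a higher number here means a weaker inhibitor of growth, a lower number a stronger inhibitor of growth:
Compound 1 `COc1ccc(-c2cc(-c3ccc([N+](=O)[O-])cc3)[nH]n2)cc1` gives 27300 nM.
Compound 2 `COc1ccc(-c2cc(-c3ccccc3)n[nH]2)cc1` gives 9900 nM.
Compound 3 `COc1ccc(-c2cc(-c3ccccc3-c3ccccc3)n[nH]2)cc1` gives 670 nM.

Compound 3 stands lowest of the three numbers in this assay. Its nearest neighbour is compound 2, and the step from compound 2 to compound 3 a 15-fold lower number from compound 2 to compound 3 (1.17 log units; beyond the scatter) lies beyond the scatter; compound 1 stands furthest away, with a higher number still. Compound 4 `FC(F)(F)c1ccc(-c2cc(-c3ccccc3-c3ccccc3)n[nH]2)cc1` keeps the whole of compound 3 except for one change: trifluoromethyl in place of methoxy on an aromatic carbon. For the measured compounds named here, no measured pair shows this exchange. Going by the values given here, the only step on record, a 15-fold lower number from compound 2 to compound 3 (1.17 log units; beyond the scatter), concerns a phenyl added to the shared core and says nothing about replacing methoxy with trifluoromethyl. Among the compounds with values here, with no step to lean on, the expectation in this assay is a change no larger than the usual scatter, in no particular direction. Compound 4 is therefore estimated at 700 nM, with a range from 250 nM to 2000 nM. This estimate means a step of a 1.0-fold higher number from compound 3 to compound 4 (0.02 log units; within the scatter), which is expected to stay within the scatter.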

Compound 4, concentration for 50% growth inhibition: 2750 nM
Compound 4: the middle estimate sits 3.9-fold (0.59 log units) below what was measured; measured number above the stated range.
By their numbers in this assay, from the lowest: compound 3; then compound 4; then compound 2; then compound 1.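

In this assay, putting trifluoromethyl in place of methoxy on this carbon of the six-membered aromatic ring, para to a large group, gives a 4.1-fold higher number from compound 3 to compound 4 (0.61 log units; beyond the scatter), so compound 4 is a weaker inhibitor of growth than compound 3. For the compounds shown here, until now the only single change on record was the added phenyl, so this is the first sign that the group at the methoxy position also affects the result, by an amount that clears the usual scatter. The exchange changes two counted features together, with the heavy atoms in the group rising and its one hydrogen-bond acceptor disappearing, and no measurement here explains the loss of activity or separates these two features.

This single pair does not show whether methoxy itself is favourable or trifluoromethyl unfavourable, and a hydroxyl group, an amine or a longer chain such as ethoxy at the same place would help tell these apart. On these data alone, it also remains open whether the same exchange would produce a step of similar size on compound 2, which lacks the added phenyl.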